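Nitro in place of trifluoromethyl on the ester aryl ring

The source may hold more compounds than are shown below. What is called first, only, known or untested is meant among the compounds shown, and "the series" means these compounds.

Compound 3 `Cc1cc2c(C(C)C)ccc(C)c2cc1OC(=O)c1ccc(C(F)(F)F)cc1` stands lowest of the three measured numbers in a functional assay on U-251 cells (Homo sapiens) for antiproliferative activity, read by sulforhodamine B assay, with a stated time of 48 h, tested at 50 uM; on this read-out higher numbers stand for more inhibition at the one concentration tested (going by the name of the read-out) and lower numbers for less inhibition: compound 3 gives 16.5%, within the scatter of compound 2 `CC1=CC[C@H](C(C)C)c2cc(C)c(OC(=O)c3ccc([N+](=O)[O-])cc3)cc21`, which gives 16.8%, and far beneath compound 1 `CC1=CC[C@H](C(C)C)c2cc(C)c(OC(=O)Nc3ccccc3)cc21`, which gives 100%. Compound 4 `Cc1cc2c(C(C)C)ccc(C)c2cc1OC(=O)c1ccc([N+](=O)[O-])cc1` differs from compound 3 by nitro in place of trifluoromethyl on an aromatic carbon. Within the data shown here, no measured step covers this exchange. Among the measured compounds shown here, the only step, a number 83.2 percentage points lower from compound 1 to compound 2 (beyond the scatter), concerns the group on the carbonyl carbon and another core, so it bears little here; the nearest guide is that compound 2, carrying nitro, and compound 3, carrying trifluoromethyl, give values within the scatter of each other. The exchange is therefore expected to give a step of a number 0.5 percentage points higher from compound 3 to compound 4 (within the scatter), not beyond the scatter. The estimate for compound 4 is 17%, ranging from 5% to 35%.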

Compound 4, a percentage reported as inhibition, at one concentration (the size of the read-out at that concentration, not a potency): 100%
Beside the measured number, compound 4's estimate is 83 percentage points below it, outside the stated range (above it).
By their numbers in this assay, from the lowest: compounds 3 and 2 (each within the scatter of the next); then compounds 1 and 4 (each within the scatter of the next).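

In this assay, among these compounds, the exchange on this aromatic carbon gives a number 83.5 percentage points higher from compound 3 to compound 4 (beyond the scatter), so on this core the single group at this place decides between little inhibition and a very high reading. Nitro alone does not fix the number, for compound 2, which carries nitro on another core, gives 16.8%. Nothing measured here accounts for the gap between the two groups. The compounds shown leave open how an amine or a nitrile on this aromatic carbon would read on this core, and whether trifluoromethyl on the core of compound 2 would read differently from nitro.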